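Chloro to Methoxy on the Shared Core of Compound 1

A few compounds are considered here, and "the series" means these few. Any claim that something is new, unique, unknown or untested is made for them only; others in the source may bear on it.

Compound 1 `CCC(C(=O)N1CCN(c2cccc(Cl)c2)CC1)N1C(=O)CCC1=O`: 75%
Compound 2 `CC(C(=O)N1CCN(c2cccc(Cl)c2)CC1)N1C(=O)CCC1=O`: 75%
Compound 3 `CCC(C(=O)N1CCOCC1)N1C(=O)CCC1=O`: 0%

In a functional assay on the whole organism (strain Swiss) with Mus musculus as the target, in the maximal electroshock model, with a stated time of 0.25 h, at a dose of 300 mg/kg by the intraperitoneal route (a lower number here means a weaker effect, a higher number a stronger effect of the compound at the dose given), compound 1 gives 75% and stands level with compound 2, the two together being the highest of the three numbers. Compound 2 gives 75%, and the step of no change at the digits printed from compound 1 to compound 2 (within the scatter) is within the scatter. Compound 3 gives 0%, far below compound 1 and beyond the scatter; compound 3 differs from compound 1 in more than one place, so no single step can be read from that pair.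

Compound 4 `CCC(C(=O)N1CCN(c2cccc(OC)c2)CC1)N1C(=O)CCC1=O` differs from compound 1 by methoxy in place of chloro on an aromatic carbon. Among the compounds with values here, none of the measured steps touches the aromatic ring: the one step that is known, from compound 1 to compound 2, lies on the saturated chain and left this assay unchanged. Nothing measured therefore speaks for a change at the aromatic carbon, and the expectation is that compound 4 lands near compound 1, with a step of a number 5 percentage points lower from compound 1 to compound 4 (within the scatter) expected to stay within the scatter. Compound 4 is thus estimated at 70%, within a range from 40% to 90%.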

Compound 4, a percentage reported as activity, at one dose (the size of the read-out at that dose, not a potency): 25%
Estimate against measurement, compound 4: 45 percentage points above; measured number below the stated range.
By their numbers in this assay, from the lowest: compound 3; then compound 4; then compounds 1 and 2 (each within the scatter of the next).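

Within the data shown here, the exchange of 3-chlorophenyl for 3-methoxyphenyl is the first change at the aromatic ring in this set, and in this assay it proves large (a number 50 percentage points lower from compound 1 to compound 4 (beyond the scatter)). This aromatic carbon therefore behaves quite differently from the saturated chain carbon, where the earlier step showed no change at the digits printed from compound 1 to compound 2 (within the scatter); on the shared core of compound 1, the effect at the dose given depends strongly on which group sits on the ring, and methoxy does not stand in for chloro. Nothing available bears on the reason for this loss, so the result stands as an observation without an explanation.

The compounds shown leave open whether chloro is special at this place or methoxy is particularly poor, since they do not say how a fluoro, methyl, trifluoromethyl or hydroxyl group would read on the same aromatic carbon. They also leave open whether methoxy in place of chloro would cost as much on the core of compound 2, where the chain differs.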